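Masking a Phenol: Expected Tolerance of Compound 3

This account rests on a few compounds, and the source may have more. Where it says the series, first, only, none or still open, it means among the compounds named here.

Measured so far:
- compound 1, `O=C(COc1cccc2ccccc12)N/N=C/c1ccc(O)cc1`: 26.5 ug/mL
- compound 2, `C/C(=N\NC(=O)COc1cccc2ccccc12)c1ccccc1O`: 11.3 ug/mL

Of the compounds shown here, two sharing the same core have been tested in an ADME assay on MT4 cells (Homo sapiens) for cytotoxicity, read by MTT assay, with a stated time of 4 days; a higher number here means that more compound is tolerated, a lower number that less compound is tolerated. Compound 1 gives 26.5 ug/mL, and compound 2 gives 11.3 ug/mL. Of these two numbers, compound 1 stands highest, meaning it is the better tolerated of the pair; the gap to compound 2 lies beyond the usual scatter of this kind of measurement. Since compound 1 and compound 2 differ in more than one place, their two values are simply recorded side by side and no single cause is drawn from them.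

The next compound, compound 3, is `COc1ccc(/C=N/NC(=O)COc2cccc3ccccc23)cc1`. Compared with compound 1 it carries one change:

methyl in place of hydrogen on an oxygen on an aromatic ring

Among the compounds with values here, no pair of measured compounds differs by this change alone, so there is no measured step to lean on. Given how small the added group is, little movement in this assay is expected, and the step of a 1.1-fold lower number from compound 1 to compound 3 (0.03 log units; within the scatter) is estimated to fall within the scatter, in no particular direction. Compound 3 is therefore expected to give about 25 ug/mL, with a likely range from 10 ug/mL to 60 ug/mL.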

Compound 3, half-maximal cytotoxic concentration: 76.9 ug/mL
Compound 3: middle estimate off by 3.1-fold (0.49 log units), on the low side; measured number above the stated range.
By their numbers in this assay, from the lowest: compound 2; then compound 1; then compound 3.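

Within the data shown here, changing hydroxy to methoxy on the 4-hydroxyphenyl group gives the first single change that can be read in this assay and produces a 2.9-fold higher number from compound 1 to compound 3 (0.46 log units; beyond the scatter) in this comparison, so more compound is tolerated once methyl replaces the hydrogen on this oxygen. A change of only one heavy atom, a single carbon, at this oxygen on an aromatic ring is therefore enough to move the number beyond the usual scatter, something the two earlier compounds could not show. No supporting measurement bears on this result, and the reason for the rise remains unknown.

As far as these compounds go, it remains open whether a longer chain on the same oxygen, such as ethyl, would move the number the same way as methyl, and what an amine in place of the hydroxy group would do. From the compounds shown here alone, compound 2 differs from compound 1 in more than one place, so it also remains open whether replacing the hydrogen on its own hydroxy group with methyl would give a similar step.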